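Removing a Methyl on Two Fused Cores

The compounds below may be only part of what the source reports. "The series", "measured", "known", "first", "only" and "open" are said of these compounds alone.

Compound 1 `CC1(C)CN(c2cccnc2)C(=O)c2ccc(Cl)cc21` reaches only the limit of an ADME assay on cells for inhibition of cytochrome P450 11B1, mitochondrial (Homo sapiens), read by HTRF (on this read-out lower numbers stand for stronger inhibition and higher numbers for weaker inhibition), > 10000 nM. Compound 2 `CC1CN(c2cccnc2)C(=O)c2ccc(Cl)cc21` gives 2590 nM in this assay. The change between them, (hydrogen in place of methyl on a saturated ring carbon), made an at least 3.8-fold lower number from compound 1 to compound 2 (0.58 log units; beyond the scatter), a step read against (the limit of > 10000 nM in this assay, at which 1 of the 3 values shown sits).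

Compound 3 `CC(=O)N[C@@H]1CCCc2c1cncc2N1C(=O)c2ccc(Cl)cc2[C@H]1C` gives 5140 nM in this assay; the difference between its core and that of compound 1 is not broken down here. Compound 4 `CC(=O)N[C@@H]1CCCc2c1cncc2N1Cc2cc(Cl)ccc2C1=O` carries the same kind of change, (hydrogen in place of methyl on a saturated ring carbon), though the place now is a five-membered non-aromatic ring with 1 nitrogen, next to the ring nitrogen and next to the ring atom that bears a large group, rather than a six-membered ring two ring bonds from the ring nitrogen.

The expectation rests on compound 1 and compound 2, whose step an at least 3.8-fold lower number from compound 1 to compound 2 (0.58 log units; beyond the scatter) ran toward a lower number. Compound 4 is therefore expected near 2000 nM, between 700 nM and 6000 nM. The expected step is a 2.6-fold lower number from compound 3 to compound 4 (0.41 log units; beyond the scatter), kept more modest than the measured one, with the changed place as the caution.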

Compound 4, half-maximal inhibitory concentration: 2330 nM
Estimate against measurement, compound 4: 1.2-fold (0.07 log units) below; low and high end bracket the measured number.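

In this assay, replacing the methyl with hydrogen on the saturated ring carbon also gave stronger inhibition on the second core, a 2.2-fold lower number from compound 3 to compound 4 (0.34 log units; beyond the scatter). The change therefore ran the same way on both cores, and the two steps compare as follows: the same change on two cores in this assay, an at least 3.8-fold lower number (0.58 log units; beyond the scatter) from compound 1 to compound 2 and a 2.2-fold lower number (0.34 log units; beyond the scatter) from compound 3 to compound 4; the limit leaves it open whether they differ. Two pairs show a shared direction only, not a shared size, and they say nothing about other cores in this series.

The compounds shown leave open whether removing the remaining methyl from compound 2 would strengthen inhibition further. They also leave open how an ethyl group, a hydroxyl group or an amine would behave on that saturated ring carbon.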